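A few compounds are considered here, and "the series" means these few. Any claim that something is new, unique, unknown or untested is made for them only; others in the source may bear on it.

Measured so far:
compound 1, `O=C(NC(=S)NCc1ccc(C(F)(F)F)cc1)c1ccccc1`: "not active" (no number reported)
compound 2, `O=C(NC(=S)NCc1cccs1)c1ccccc1`: 47%

Going by the values given here, in an assay on isolated protein for inhibition of polyamine deacetylase HDAC10 (Homo sapiens), read by fluorescence, tested at 100 uM (on this read-out lower numbers stand for less inhibition and higher numbers for more inhibition at the one concentration tested (going by the name of the read-out)), compound 2 gives 47%, the only number; compound 1 has an entry without a number. Compound 3, `O=C(NC(=S)NCc1ccccc1)c1ccccc1`, is not yet measured. It differs from compound 2 by phenyl in place of thiophen-2-yl on a saturated chain carbon bound to an amide-type nitrogen. Among the compounds with values here, no step between measured compounds is available, so the expectation rests on the change alone: a small shift downward, if any, is expected here, a number 7 percentage points lower from compound 2 to compound 3 (within the scatter), and it is estimated to stay within the scatter. Compound 3 is expected at about 40%, with a range from 20% to 58%.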

Compound 3, a percentage reported as inhibition, at one concentration (the size of the read-out at that concentration, not a potency): "not active" (no number reported)
No number was reported for compound 3, so the estimate cannot be set against anything.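

Going by these compounds alone, with compound 3 reported without a number in this assay, no step from compound 2 to compound 3 can be read. The compounds shown leave open how far phenyl in place of thiophen-2-yl shifts inhibition. No evidence bears on this result.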